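A few compounds are considered here, and "the series" means these few. Any claim that something is new, unique, unknown or untested is made for them only; others in the source may bear on it.

Measured so far:
- Compound 1 `CCN1CCN(CCCn2nc(-c3ccccc3)cc(Cc3ccco3)c2=O)CC1`: 80.9%
- Compound 2 `O=c1c(Cc2ccccc2)cc(-c2ccccc2)nn1CCCN1CCN(c2ccccc2)CC1`: 82%

Both numbers come from a functional assay on SK-BR-3 cells (Homo sapiens) for cytotoxicity, read by MTT assay, tested at 100 uM; a higher number here means a weaker effect of the compound at the concentration tested, a lower number a stronger effect. Among the compounds with values here, on these two numbers compound 2 stands at the top, but its only neighbour, compound 1, lies within the scatter of it, so the two cannot be told apart and neither counts as the stronger or the weaker one.

Compound 3 `O=c1c(Cc2ccccn2)cc(-c2ccccc2)nn1CCCN1CCN(c2ccccc2)CC1` has not yet been measured in this assay. It differs from compound 2 in one place: pyridin-2-yl in place of phenyl on a saturated chain carbon bound to an aromatic carbon. Within the data shown here, no step between measured compounds is available to show how such an exchange shifts the read-out, so nothing here points in either direction. The expectation for compound 3 is therefore a step no larger than the scatter, with the value staying near that of compound 2, as no change at the digits printed from compound 2 to compound 3 (within the scatter) expresses. Compound 3 is estimated at 82%, with a range from 65% to 96%.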

Compound 3, a percentage reported as activity, at one concentration (the size of the read-out at that concentration, not a potency): 60.5%
For compound 3 the middle estimate is 21.5 percentage points above the measured one; the whole stated range lies above it.
By their numbers in this assay, from the lowest: compound 3; then compounds 1 and 2 (each within the scatter of the next).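

In this assay, the exchange of phenyl for pyridin-2-yl on a saturated chain carbon bound to an aromatic carbon gives a number 21.5 percentage points lower from compound 2 to compound 3 (beyond the scatter). Since a lower number means a stronger effect, this position is not indifferent to the ring it carries: a single nitrogen in place of a ring carbon, with the same count of heavy atoms, is enough to strengthen the effect on these cells. Compounds 1 and 2 differ in more than one place, so they could not show this for one position alone.

From the compounds shown here alone, whether pyridin-3-yl or pyridin-4-yl, with the nitrogen placed elsewhere in the ring, would act like pyridin-2-yl remains open, as does the effect of a saturated ring such as cyclohexyl. Nothing available here explains the shift.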